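Methyl in Place of Fluoro: Will the Limit Hold?

This account rests on a few compounds, and the source may have more. Where it says the series, first, only, none or still open, it means among the compounds named here.

Compound 1, `Fc1cccc(-c2nc(Nc3ccccc3F)c3cc(F)ccc3n2)c1`, was tested in a functional assay on COLO 205 cells (Homo sapiens) for cytotoxicity, read by MTT assay, with a stated time of 48 h; on this read-out higher numbers stand for weaker inhibition and lower numbers for stronger inhibition. In this assay compound 1 gives only a limit, > 50000 nM, so no number is known for it. Compound 2, `Cc1ccc(Nc2nc(-c3cccc(F)c3)nc3ccc(F)cc23)cc1`, carries 4-methylphenyl in place of 2-fluorophenyl on a nitrogen on an aromatic ring. In this assay compound 2 likewise gives only a limit, > 50000 nM. The step that the two limits leave unreadable from compound 1 to compound 2 therefore has no readable size, since both of its ends sit at the same limit, as the limit of > 50000 nM in this assay, at which 2 of the 2 values shown sit, records.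

Compound 3, `Cc1ccccc1Nc1nc(-c2cccc(F)c2)nc2ccc(F)cc12`, is the compound still to be measured. Its difference from compound 1 is methyl in place of fluoro on an aromatic carbon. Going by the values given here, the single measured step, from compound 1 to compound 2, alters the same phenyl group but cannot be sized, so no measured step shows how this assay answers a change at that ring. Among the compounds with values here, the only guide is that both measured compounds rest at the limit. Compound 3 is therefore expected to stay at the limit too, and its step that the limit leaves unreadable from compound 1 to compound 3 is expected to show nothing beyond the scatter. The estimate for compound 3 is 60000 nM, with an expected range from 25000 nM to 150000 nM.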

Compound 3, half-maximal inhibitory concentration: > 50000 nM
Compound 3: only a limit was reported; the forecaster's own chance of this, stated with the estimate: 85%; the middle value does not contradict the limit.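

Compound 3 gives only a limit in this assay, so neither the step to it from compound 1 nor the step to it from compound 2 can be read: the limit of > 50000 nM in this assay, at which 3 of the 3 values shown sit. The compounds shown leave open how strong compound 1, compound 2 and compound 3 really are, and whether any change on this phenyl group moves the value.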